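The source may hold more compounds than are shown below. What is called first, only, known or untested is meant among the compounds shown, and "the series" means these compounds.

Of the compounds shown here, three sharing one core have been measured in a functional assay on MDA-MB-231 cells (Homo sapiens) for antiproliferative activity, read by CCK-8 assay, with a stated time of 72 h; on this read-out higher numbers stand for weaker inhibition and lower numbers for stronger inhibition. Compound 1 `O=C(Nc1cccc(-c2oc3cc(-c4ccc(F)cc4)ccc3c(=O)c2O)c1)c1ccc(Br)cc1` carries a bromo group on its outer aromatic ring and gives 24900 nM. Compound 2 `CCc1ccc(C(=O)Nc2cccc(-c3oc4cc(-c5ccc(F)cc5)ccc4c(=O)c3O)c2)cc1` replaces that bromo group with ethyl and gives 9070 nM, a change of a 2.7-fold lower number from compound 1 to compound 2 (0.44 log units; beyond the scatter). Compound 3 `O=C(Nc1cccc(-c2oc3cc(-c4ccc(F)cc4)ccc3c(=O)c2O)c1)c1cc(F)cc(F)c1` carries a 3,5-difluorophenyl on the carbonyl carbon instead and gives 2440 nM, which is the lowest number of the three, with a 10-fold lower number from compound 1 to compound 3 (1.01 log units; beyond the scatter) and a 3.7-fold lower number from compound 2 to compound 3 (0.57 log units; beyond the scatter).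

Compound 4 `O=C(Nc1cccc(-c2oc3cc(-c4ccc(F)cc4)ccc3c(=O)c2O)c1)c1ccc([N+](=O)[O-])cc1` has not yet been measured. It differs from compound 3 by 4-nitrophenyl in place of 3,5-difluorophenyl on a carbonyl carbon. Both earlier steps on the carbonyl carbon changed the number beyond the scatter, and in both the 3,5-difluorophenyl came out with the lower number; the 4-bromophenyl of compound 1 and the 4-ethylphenyl of compound 2 sat higher. Nothing measured here tells how a 4-nitrophenyl behaves, so the expectation is drawn from the spread of those three values. Compound 4 is therefore expected to move back toward the higher numbers, with a step of a 2.5-fold higher number from compound 3 to compound 4 (0.39 log units; beyond the scatter), and to give about 6000 nM, most likely between 1500 nM and 24000 nM.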

Compound 4, half-maximal inhibitory concentration: 14700 nM
Beside the measured number, compound 4's estimate is 2.5-fold (0.39 log units) below it, within the range that was stated.
By their numbers in this assay, from the lowest: compound 3; then compounds 2, 4 and 1 (each within the scatter of the next, the first and the last beyond it).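

In this assay, replacing the 3,5-difluorophenyl on this carbonyl carbon with 4-nitrophenyl gives a 6.0-fold higher number from compound 3 to compound 4 (0.78 log units; beyond the scatter) and so weakens the inhibition. This makes compound 3 the most potent of the four, with its number now clearly lower than those of all three compounds carrying a single group on the outer ring: 4-bromophenyl, 4-ethylphenyl and 4-nitrophenyl. Those single groups are harder to separate than the first two compounds suggested, for nitro in place of ethyl gives a 1.6-fold higher number from compound 2 to compound 4 (0.21 log units; within the scatter) and nitro in place of bromo gives a 1.7-fold lower number from compound 1 to compound 4 (0.23 log units; within the scatter), so compound 4 cannot be told apart from either, even though compound 1 and compound 2 differ from each other; no measurement here explains why the groups differ.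

As far as these compounds go, it remains open whether one fluorine would be enough, as a 3-fluorophenyl or a 4-fluorophenyl on the same carbonyl carbon would show, or whether the 3,5-difluorophenyl arrangement itself matters. From the compounds shown here alone, how an amine, a carboxylic acid or a methoxy group on this outer ring would compare with compound 3 also stays unknown.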